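The compounds below may be only part of what the source reports. "The series", "measured", "known", "first", "only" and "open" are said of these compounds alone.

Measured in a functional assay on KMS-11 cells (Homo sapiens), read by neutral red uptake, with a stated time of 48 h; a lower number here means a stronger inhibitor, a higher number a weaker inhibitor:

compound 1, `Nc1nccc(-c2c[nH]c3nc(Br)ccc23)n1`, gives > 15000 nM, a limit of the assay.
compound 2, `COCCOc1ccnc2[nH]cc(-c3ccnc(N)n3)c12`, gives > 20000 nM, a limit of the assay.
compound 3, `Cn1cc(-c2ccnc(N)n2)c2c(O)ccnc21`, gives > 20000 nM, a limit of the assay.

None of the three compounds returns a number in this assay. Compound 2 stands at the limit of > 20000 nM in this assay, at which 2 of the 3 values shown sit, and compound 3 sits at the same limit. Compound 1 sits at the limit of > 15000 nM in this assay, at which 1 of the 3 values shown sits. With only limits shown, nothing can be said about the order of the three, and no step between measured compounds is available to lean on.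

Compound 4, `CCCOc1ccnc2[nH]cc(-c3ccnc(N)n3)c12`, differs from compound 2 by a single change: methyl in place of methoxy on a saturated chain carbon, two bonds along the chain from an oxygen on an aromatic ring. The chain keeps its length and its attachment through the oxygen on the aromatic ring; only the outer end of the chain is altered.

Since compound 2 gives no number, no step can be computed, and the expectation for compound 4 rests on the fact that every compound shown, including compound 2 with > 20000 nM, lies at a limit. The expected step from compound 2 to compound 4 is a step that the limit leaves unreadable from compound 2 to compound 4, which is to say none beyond the scatter. Compound 4 is therefore estimated at 25000 nM, between 8000 nM and 60000 nM, most likely again returned as a limit rather than a number.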

Compound 4, half-maximal inhibitory concentration: 40 nM
Compound 4: the middle estimate sits 630-fold (2.80 log units) above what was measured; the measured number lies below the stated range.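

In this assay, going by these compounds alone, methyl in place of methoxy on a saturated chain carbon, two bonds along the chain from an oxygen on an aromatic ring, gives an at least 500-fold lower number from compound 2 to compound 4 (2.69 log units; beyond the scatter), a large step beyond the scatter and the first readable number. The earlier compounds shown here, which offered only limits, gave no sign that any change could bring a number in this assay; this single pair shows that the outer end of the chain can decide the outcome, with the chain's length and its attachment through the oxygen unchanged. Compound 2 remains a limit of the assay and not a number, so the step is itself a bound and its full size cannot be read: the limit of > 20000 nM in this assay, at which 2 of the 4 values shown sit.

What the pair leaves open is how far this holds beyond propoxy, since one change cannot separate the loss of the methoxy from the arrival of the methyl. From the compounds shown here alone, whether ethoxy, a longer chain such as butoxy, or an amine at the end of the chain would keep a number of this order remains open, and compound 1 and compound 3 differ from compound 4 in more than one place, so they cannot settle it.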